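Taking the Side Chain off Compound 1

A few compounds are considered here, and "the series" means these few. Any claim that something is new, unique, unknown or untested is made for them only; others in the source may bear on it.

In a functional assay on Fem-X cells (Homo sapiens) for cytotoxicity, read by MTT assay, with a stated time of 72 h (a lower number here means a stronger inhibitor, a higher number a weaker inhibitor), compound 1 `CC(C)(C)C1=CC(=O)C=C(NCCC(=O)O)C1=O` gives 28400 nM. Compound 2 `CC1=CCC[C@H]2[C@](C)(CC3=CC(=O)C=CC3=O)[C@@H](C)CC[C@]12C` gives 40300 nM, and compound 3 `CSCC[C@H](NC1=CC(=O)C=C(C[C@]2(C)[C@@H](C)CC[C@]3(C)C(C)=CCC[C@@H]23)C1=O)C(=O)O` gives 19400 nM. The number for compound 1 lies within the usual scatter of both the others, so it cannot be ranked against either.

For the measured compounds named here, compound 4 `CC(C)(C)C1=CC(=O)C=CC1=O` has no measurement yet. It differs from compound 1 by one change, hydrogen in place of (2-carboxyethyl)amino on a double-bonded ring carbon.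

Going by the values given here, only one measured step bears on this: a 2.1-fold lower number from compound 2 to compound 3 (0.32 log units; beyond the scatter), where (1-carboxy-3-(methylsulfanyl)propyl)amino takes the place of hydrogen on a double-bonded ring carbon. That step puts a carboxy-bearing amino chain on, whereas the change to compound 4 takes one off, so the number is expected to move the opposite way. The chains and the cores differ between the two cases, which makes this a rough guide only. The expected change is modest and near the edge of the scatter: an estimated 1.8-fold higher number from compound 1 to compound 4 (0.25 log units; within the scatter). For compound 4, the estimated value in this assay is 50000 nM, with an expected range of 15000 nM to 110000 nM.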

Compound 4, half-maximal inhibitory concentration: 41600 nM
The estimate for compound 4 lay 1.2-fold (0.08 log units) above the measured number; the range from low to high includes it.
By their numbers in this assay, from the lowest: compounds 3, 1, 2 and 4 (each within the scatter of the next, the first and the last beyond it).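

In this assay, taking the (2-carboxyethyl)amino chain off the double-bonded ring carbon and leaving hydrogen gives a 1.5-fold higher number from compound 1 to compound 4 (0.17 log units; within the scatter), so compound 1 and compound 4 cannot be ranked against each other. The earlier compounds shown here offered only a different chain on a different core, whereas this pair tests the place on the core of compound 1 itself: here, the whole chain can go without a difference that stands clear of the scatter. Nothing available explains this outcome.

Still open, from the compounds shown here alone, is whether a plain amine on this carbon, or a longer chain ending in a carboxylic acid, would stand clear of compound 4 in this assay. Also open, going by these compounds, is whether replacing the tert-butyl group with a methyl group would alter how little this change matters.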